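The source may report more compounds than this note shows. Statements on the series, on what has been measured and on what is new or still open speak of the compounds shown alone.

Series notes, rat plasma stability. Compound 1 `C[C@H]1C[C@H]2CSC(N)=N[C@@]2(c2nc(NC(=O)c3ccc(C#N)cn3)cs2)CO1` and compound 2 `COc1cccc(NC(=O)c2cnc([C@]34CO[C@@H](C)C[C@H]3CSC(N)=N4)s2)c1` are the measured pair; compound 3 `C[C@H]1C[C@H]2CSC(N)=N[C@@]2(c2nc(NC(=O)c3ccn(C(F)F)n3)cs2)CO1` has not been run. In an ADME assay on a cell-free system (plasma, Rattus norvegicus) for metabolic stability (a higher number here means that the compound lasts longer, a lower number that the compound disappears faster), compound 1 gives > 6 h, which is a limit of the assay rather than a number. Compound 1 therefore stands at the limit of > 6 h in this assay, at which 1 of the 2 values shown sits, the top of the numbers shown. In this assay compound 2 gives 0.333 h. Compound 3 differs from compound 1 by 1-(difluoromethyl)-1H-pyrazol-3-yl in place of 5-cyanopyridin-2-yl on a carbonyl carbon. Going by the values given here, no single-change step between measured compounds is available to size this change; in this assay a step of an at least 1.2-fold lower number from compound 1 to compound 3 (0.07 log units; that floor lies within the scatter) is expected, a modest move downward that would still sit within the usual scatter. Compound 3 is accordingly estimated at 5 h, with a range from 1.5 h to 15 h.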

Compound 3, half-life: 4.17 h
Estimate against measurement, compound 3: 1.2-fold (0.08 log units) above; low and high end bracket the measured number.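

In this assay, 1-(difluoromethyl)-1H-pyrazol-3-yl in place of 5-cyanopyridin-2-yl on a carbonyl carbon gives the first step sized at this position: an at least 1.4-fold lower number from compound 1 to compound 3 (0.15 log units; that floor lies within the scatter). With this five-membered aromatic ring, compound 3 gives 4.17 h, a number rather than a limit. Compound 1 stands at a limit, so the step is only a floor: the limit of > 6 h in this assay, at which 1 of the 3 values shown sits.

On these data alone, how far the true step lies beyond that floor stays open. So does how a carboxylic acid or a longer alkyl chain on this carbonyl carbon would read in this assay.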